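This account rests on a few compounds, and the source may have more. Where it says the series, first, only, none or still open, it means among the compounds named here.

Measured in a functional assay on CCRF-CEM cells (Homo sapiens) for antiproliferative activity, with a stated time of 72 h; on this read-out lower numbers stand for stronger inhibition and higher numbers for weaker inhibition:
- Compound 1 `OC[C@H]1O[C@@H](n2cnc3c(NCc4ccc(F)cc4)ncnc32)[C@H](O)[C@@H]1O`: 1250 nM
- Compound 2 `COc1cccc(CNc2ncnc3c2ncn3[C@@H]2O[C@H](CO)[C@@H](O)[C@H]2O)c1OC`: > 166000 nM (a limit, not a number)

Compound 2 stands at the limit of > 166000 nM in this assay, at which 1 of the 2 values shown sits. Its true position is therefore unknown, and only a limit is available for it. Compound 3 `COc1ccc(CNc2ncnc3c2ncn3[C@@H]2O[C@H](CO)[C@@H](O)[C@H]2O)c(OC)c1` keeps the shared core and has the same atoms as compound 2, joined differently: 2,4-dimethoxyphenyl in place of 2,3-dimethoxyphenyl on a saturated chain carbon bound to a nitrogen on an aromatic ring.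

Going by the values given here, one measured step bears on this change, at the same place on the chain: an at least 130-fold higher number from compound 1 to compound 2 (2.12 log units; beyond the scatter). That large step shows that the group at this place can move the number far, but it does not compare two dimethoxyphenyl groups. Compound 3 still carries a dimethoxyphenyl group rather than the 4-fluorophenyl of compound 1, which gives 1250 nM, so a full return to that level is not expected. A moderate step toward lower numbers in this assay is expected, though the assay may again report only a limit. The estimated step is an at least 2.7-fold lower number from compound 2 to compound 3 (0.44 log units; beyond the scatter), well short of the measured one. For compound 3 the expected value is 60000 nM. The estimated range for compound 3 runs from 10000 nM to 166000 nM.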

Compound 3, half-maximal inhibitory concentration: > 166000 nM
Compound 3 gave a limit, no number; the forecaster's own chance of this, stated with the estimate: 55%; middle value at least 2.7-fold (0.44 log units) from the limit.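

Compound 3 gives only a limit in this assay, not a number, and so does compound 2, so the step between them cannot be read and the change from 2,3-dimethoxyphenyl to 2,4-dimethoxyphenyl has no measurable size here. Replacing 4-fluorophenyl with 2,4-dimethoxyphenyl on the saturated chain carbon gives an at least 130-fold higher number from compound 1 to compound 3 (2.12 log units; beyond the scatter), so the large rise in the number is no longer tied to the 2,3-dimethoxyphenyl arrangement alone and holds for both dimethoxyphenyl groups shown. The assay does not separate these two isomers, which share a single reading: the limit of > 166000 nM in this assay, at which 2 of the 3 values shown sit.

On these data alone, how far compound 2 and compound 3 lie beyond that limit remains unknown, so any real difference between the two arrangements stays hidden. As far as these compounds go, it is also open whether the large step depends on carrying two methoxy groups or on losing the 4-fluorophenyl group, a question that a single methoxy group, an unsubstituted phenyl or a 4-chlorophenyl at this place on the chain would bear on.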